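Compound 3 to compound 4: cytotoxicity at the limit

The source may report more compounds than this note shows. Statements on the series, on what has been measured and on what is new or still open speak of the compounds shown alone.

Measured in a functional assay on HEK293 cells (Homo sapiens) for cytotoxicity; a lower number here means that less compound is tolerated, a higher number that more compound is tolerated:
- Compound 1 `COc1ccc([C@H]2CC(=O)N(c3cccc(C)c3)C2)cc1OC1CCCC1`: > 10000 nM, a limit
- Compound 2 `COc1ccc([C@H]2CC(=O)N(c3cccc(NS(=O)(=O)c4ccccc4C)c3)C2)cc1OC1CCCC1`: > 10000 nM, a limit
- Compound 3 `COc1ccc([C@H]2CC(=O)N(c3cccc(NS(=O)(=O)c4cc(Br)c(Cl)s4)c3)C2)cc1OC1CCCC1`: > 10000 nM, a limit

The measured series offers only (the limit of > 10000 nM in this assay, at which 3 of the 3 values shown sit). Compound 3 thus has no number, only the limit > 10000 nM.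

Compound 4 `COc1ccc([C@H]2CC(=O)N(c3cccc(NS(=O)(=O)c4c(Br)nn(C)c4Cl)c3)C2)cc1OC1CCCC1` differs from it in the group on a sulfonyl sulfur whose other neighbour is the sulfonamide nitrogen: 3-bromo-5-chloro-1-methyl-1H-pyrazol-4-yl in place of 4-bromo-5-chlorothiophen-2-yl on a sulfonyl sulfur.

Within the data shown here, three measured steps bear on this change: a step that the two limits leave unreadable from compound 1 to compound 2, a step that the two limits leave unreadable from compound 1 to compound 3 and a step that the two limits leave unreadable from compound 2 to compound 3. Among the measured compounds shown here, the last is the closest precedent, since it too exchanges the group on a sulfonyl sulfur. None of the three has a readable size, but all of these compounds remain at the limit. The expected change in this assay is a step that the limit leaves unreadable from compound 3 to compound 4, with no step beyond the scatter and no favoured direction. The assay is expected to report only a limit again. For compound 4 the estimate is 20000 nM, with an expected range from 8000 nM to 50000 nM.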

Compound 4, half-maximal cytotoxic concentration: > 10000 nM
Compound 4: no number, only a limit; the forecaster's own chance of this, stated with the estimate: 88%; the middle value does not contradict the limit.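

In this assay compound 4 gives > 10000 nM as a limit, so no step among compound 1, compound 2, compound 3 and compound 4 can be read: the limit of > 10000 nM in this assay, at which 4 of the 4 values shown sit.

The compounds shown leave open at what concentration, if any, each becomes cytotoxic to these cells, and whether the group on the sulfonyl sulfur alters it.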